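The source may report more compounds than this note shows. Statements on the series, on what has been measured and on what is new or still open speak of the compounds shown alone.

Measured in a functional assay on MCF7 cells (Homo sapiens) for inhibition, read by fluorescence, with a stated time of 72 h; a higher number here means a weaker inhibitor, a lower number a stronger inhibitor:

- Compound 1 `CC[C@H](CO)Nc1nc(NC(=N)N)c2ncn(C(C)C)c2n1` gives 4500 nM
- Compound 2 `CC[C@@H](CO)Nc1nc(NC(=N)N)c2ncn(C(C)C)c2n1` gives 1600 nM

Compound 2, at 1600 nM, has the lower number of the pair and so is the stronger inhibitor of the two. The next compound to be tested is compound 3 `CC(C)[C@@H](N)COc1nc(NC(=N)N)c2ncn(C(C)C)c2n1`. It keeps the shared core but carries 2-amino-3-methylbutoxy in place of (1-(hydroxymethyl)propyl)amino on an aromatic carbon, between two ring nitrogen atoms: 2-amino-3-methylbutoxy in place of (1-(hydroxymethyl)propyl)amino on an aromatic carbon.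

Within the data shown here, only one measured step is available as a guide, a 2.8-fold lower number from compound 1 to compound 2 (0.45 log units; beyond the scatter). That modest step concerns a single stereocentre at a saturated chain carbon, and what stands behind it is the fact that one of compounds 1 and 2 is drawn with a defined configuration and the other without, at the place where they differ. It shows that this chain matters enough for a change in configuration alone to move the number, but it does not measure the exchange of a whole group. No direction can be drawn from it, so no clear change is expected in this assay, though the uncertainty is wide.

The expected size of the change is a 1.1-fold lower number from compound 2 to compound 3 (0.03 log units; within the scatter).

Compound 3 is estimated at 1500 nM, with an expected range from 400 nM to 5500 nM.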

Compound 3, half-maximal inhibitory concentration: 79400 nM
Compound 3: middle estimate off by 53-fold (1.72 log units), on the low side, and the stated range ends below it.
By their numbers in this assay, from the lowest: compound 2; then compound 1; then compound 3.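

In this assay, replacing (1-(hydroxymethyl)propyl)amino with 2-amino-3-methylbutoxy on this aromatic carbon gives a 50-fold higher number from compound 2 to compound 3 (1.70 log units; beyond the scatter) and an 18-fold higher number from compound 1 to compound 3 (1.25 log units; beyond the scatter). Both steps are large, and they are well beyond the modest 2.8-fold lower number from compound 1 to compound 2 (0.45 log units; beyond the scatter) seen when only the stereocentre of the chain differs, so exchanging the whole group at this place weakens inhibition far more than the difference in configuration does. Nothing in the available evidence accounts for the size of this loss.

The exchange alters several things at once: the chain is joined to the shared core through oxygen instead of nitrogen, it ends in an amine instead of a hydroxyl group, and its carbon branching differs, so the compounds shown cannot say which of these changes carries the loss. From the compounds shown here alone, it also remains open how an ether-linked chain ending in a hydroxyl group, or a nitrogen-linked chain ending in an amine, would read in this assay.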